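Swapping the Piperidine Amide in a Spiro Series

This account rests on a few compounds, and the source may have more. Where it says the series, first, only, none or still open, it means among the compounds named here.

Measured compounds:
- Compound 1 `CCOC(=O)C1CCN(C(=O)CN2CN(c3ccccc3)C3(CCN(C(=O)c4ccc(C5CCCCC5)cc4)CC3)C2=O)CC1`: 900 nM
- Compound 2 `CC(C)(C)c1ccc(C(=O)N2CCC3(CC2)C(=O)N(CC(=O)NCCO)CN3c2ccccc2)cc1`: 1000 nM
- Compound 3 `CC1CCCN(C(=O)CN2CN(c3ccccc3)C3(CCN(C(=O)c4ccc(C(C)(C)C)cc4)CC3)C2=O)C1`: 12000 nM

In an assay on HEK293 cells for displacement of a labelled ligand from NPC1-like intracellular cholesterol transporter 1 (Homo sapiens) (on this read-out higher numbers stand for weaker inhibition and lower numbers for stronger inhibition), compound 3 gives the highest number of the three measured compounds, so it is the weakest inhibitor in this group. Compound 2 sits closest, and compound 1 is furthest away; both of these steps lie beyond the scatter.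

Compound 4 `CCOC(=O)C1CCN(C(=O)CN2CN(c3ccccc3)C3(CCN(C(=O)c4ccc(C(C)(C)C)cc4)CC3)C2=O)CC1` is not yet measured. It differs from compound 3 in one place: 4-(ethoxycarbonyl)piperidin-1-yl in place of 3-methylpiperidin-1-yl on a carbonyl carbon. Among the compounds with values here, compound 1 carries this same 4-(ethoxycarbonyl)piperidin-1-yl group on the same carbonyl carbon, though it differs from compound 3 in a second place as well, so no single step links the two; its value simply shows that this group is compatible with a low number. Within the data shown here, the one measured step touching this position, a 12-fold higher number from compound 2 to compound 3 (1.08 log units; beyond the scatter), shows that the 3-methylpiperidin-1-yl group goes with a clearly higher number than the (2-hydroxyethyl)amino group. Replacing it is therefore expected to bring the number down again, with an estimated step of a 12-fold lower number from compound 3 to compound 4 (1.08 log units; beyond the scatter) in this assay. Compound 4 is expected to give about 1000 nM, within a range of 400 nM to 3000 nM.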

Compound 4, half-maximal inhibitory concentration: 3100 nM
Estimate against measurement, compound 4: 3.1-fold (0.49 log units) below, outside the stated range (above it).
By their numbers in this assay, from the lowest: compounds 1 and 2 (each within the scatter of the next); then compound 4; then compound 3.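

In this assay the 4-(ethoxycarbonyl)piperidin-1-yl group makes up only part of the difference: the swap gives a 3.9-fold lower number from compound 3 to compound 4 (0.59 log units; beyond the scatter) but still leaves a 3.1-fold higher number from compound 2 to compound 4 (0.49 log units; beyond the scatter) when set against the (2-hydroxyethyl)amino group on the same carbonyl carbon. Both piperidine groups carry one six-membered non-aromatic ring, yet they give clearly different numbers, so the ring alone does not set the value at this position. The low number of compound 1 also does not come from the ester-bearing group alone, since tert-butyl in place of cyclohexyl on an aromatic carbon gives a 3.4-fold higher number from compound 1 to compound 4 (0.54 log units; beyond the scatter) with that group unchanged.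

Going by these compounds, it remains open how a piperidine carrying a carboxylic acid or an amine would behave on this carbonyl carbon, or how cyclohexyl would pair with the (2-hydroxyethyl)amino group. Nothing measured here gives a reason for any of these steps.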